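Hydroxy for chloro on the aryl of compound 1

The compounds below may be only part of what the source reports. "The series", "measured", "known", "first", "only" and "open" are said of these compounds alone.

Measured so far in an assay on cells for displacement of a labelled ligand from adenosine receptor A1 (Homo sapiens), read by scintillation counting and radioligand binding, with a stated time of 60 min, tested at 10 uM; on this read-out lower numbers stand for less inhibition and higher numbers for more inhibition at the one concentration tested (going by the name of the read-out):
compound 1 `CN1CCN(c2nc(-c3cccc(Cl)c3)nc3[nH]cnc23)CC1` gives > 80%, a limit of the assay.
compound 2 `CN1CCN(c2nc(-c3ccc(Cl)c(Cl)c3)nc3c2ncn3C)CC1` gives 65.2%.
compound 3 `CN1CCN(c2nc(-c3ccccc3O)nc3c2ncn3C)CC1` gives > 80%, a limit of the assay.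

Going by the values given here, compound 1 sits at the limit of > 80% in this assay, at which 2 of the 3 values shown sit, so only a lower bound is known for it, and compound 2 is the one compound with a plain number. The step to compound 4 `CN1CCN(c2nc(-c3cccc(O)c3)nc3[nH]cnc23)CC1` is hydroxy in place of chloro on an aromatic carbon, reading one bond further out as 3-chlorophenyl to 3-hydroxyphenyl.

Among the compounds with values here, no measured pair shows exactly this exchange on the core of compound 1. The nearest comparison is a number at least 14.8 percentage points higher from compound 2 to compound 3 (beyond the scatter), where a hydroxy-bearing aryl replaced a chloro-bearing one on a different core and the reading moved from a number up to the limit. That step and the standing of compound 1 together point to compound 4 remaining at or near the limit, with no reason in the data for a drop beyond the scatter. The expected step is a step that the limit leaves unreadable from compound 1 to compound 4, so the estimate for compound 4 in this assay is 85%, with a range from 65% to 100%, and most likely the assay again reports only the limit.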

Compound 4, a percentage reported as inhibition, at one concentration (the size of the read-out at that concentration, not a potency): > 80%
Compound 4 was reported as a limit (the forecaster's own chance of this, stated with the estimate: 70%); the middle value lies beyond the limit too.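

In this assay, the step from compound 1 to compound 4 cannot be read, since both compounds stand at a limit of the assay and not at a number: the limit of > 80% in this assay, at which 3 of the 4 values shown sit.

The compounds shown leave open whether hydroxy in place of chloro on the core of compound 1 changes the inhibition at all in this assay.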